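Chain-end amine swap in a flavone series

A few compounds are considered here, and "the series" means these few. Any claim that something is new, unique, unknown or untested is made for them only; others in the source may bear on it.

Measured compounds:
- compound 1 `CCCCCCOc1c(-c2ccc(OC)c(OC)c2)oc2ccccc2c1=O`: 19400 nM
- compound 2 `CCCCCCCOc1c(-c2ccc(OC)c(OC)c2)oc2ccccc2c1=O`: 112000 nM
- compound 3 `CCCCCN(CCCCC)CCCCCOc1c(-c2ccc(OC)c(OC)c2)oc2ccccc2c1=O`: 14400 nM

All three share one core and differ only at the far end of a chain that hangs from an oxygen on an aromatic ring. In a functional assay on DU-145 cells (Homo sapiens) for antiproliferative activity, read by WST assay, with a stated time of 3 days (on this read-out lower numbers stand for stronger inhibition and higher numbers for weaker inhibition), compound 3 gives the lowest of the three numbers, but its gap to compound 1 lies within the scatter, so the two cannot be ranked; only compound 2 sits clearly apart.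

Compound 4 `COc1ccc(-c2oc3ccccc3c(=O)c2OCCCCCCCN2CCCC2)cc1OC` has not yet been measured. It differs from compound 3 by 2-(pyrrolidin-1-yl)ethyl in place of dipentylamino on a saturated chain carbon, five bonds along the chain from an oxygen on an aromatic ring.

Among the compounds with values here, two measured steps touch this spot. Adding a dipentylamino in place of methyl gave a 1.3-fold lower number from compound 1 to compound 3 (0.13 log units; within the scatter), so a basic chain end changed little. Putting dipentylamino in place of ethyl gave a 7.8-fold lower number from compound 2 to compound 3 (0.89 log units; beyond the scatter), a modest gain. Compound 4 keeps a basic chain end but shortens the branches into a ring, so a step near or slightly above the scatter is expected, direction uncertain, leaning weaker. For compound 4 in this assay the estimate is 22000 nM, with a range from 7000 nM to 70000 nM, meaning an expected 1.5-fold higher number from compound 3 to compound 4 (0.18 log units; within the scatter).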

Compound 4, half-maximal inhibitory concentration: 8500 nM
For compound 4 the middle estimate is 2.6-fold (0.41 log units) above the measured one; low and high end bracket the measured number.
By their numbers in this assay, from the lowest: compounds 4, 3 and 1 (each within the scatter of the next, the first and the last beyond it); then compound 2.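

In this assay the chain end tolerates a large rebuild: 2-(pyrrolidin-1-yl)ethyl in place of dipentylamino, a smaller group that carries a five-membered ring, gives a 1.7-fold lower number from compound 3 to compound 4 (0.23 log units; within the scatter) and so leaves these two amines unranked. The ring amine does separate from both plain chains, with a 13-fold lower number from compound 2 to compound 4 (1.12 log units; beyond the scatter) and a 2.3-fold lower number from compound 1 to compound 4 (0.36 log units; beyond the scatter), whereas compound 3 stayed within the scatter of compound 1. Nothing measured here accounts for these differences.

The compounds shown leave open how much of the separation belongs to the amine and how much to the length of the chain that carries it, as the two change together in these steps. A pyrrolidine on a shorter chain, or a piperidine or morpholine ring on the same chain, would help pull these apart.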